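This account rests on a few compounds, and the source may have more. Where it says the series, first, only, none or still open, it means among the compounds named here.

Measured in a functional assay on ECa-109 cells for inhibition, with ECa-109 cell line (Homo sapiens) as the target, read by MTT assay, with a stated time of 48 h; on this read-out lower numbers stand for stronger inhibition and higher numbers for weaker inhibition:
- Compound 1 `CCN1CCN(C(=S)SCCCOc2ccc3c(=O)c(-c4ccc(OC)cc4)coc3c2)CC1`: 36900 nM
- Compound 2 `COc1ccc(-c2coc3cc(OCCCSC(=S)N4CCN(C(=O)OC(C)(C)C)CC4)ccc3c2=O)cc1`: 3540 nM

Compound 1 has the higher of these two numbers, so it is the weaker inhibitor of the pair. Compound 3 `COc1ccc(-c2coc3cc(OCCCSC(=S)N4CCOCC4)ccc3c2=O)cc1` keeps the core of compound 1 but carries morpholin-4-yl in place of 4-ethylpiperazin-1-yl on a thiocarbonyl carbon. Among the compounds with values here, only one measured step offers a guide: tert-butoxycarbonyl in place of ethyl on an amine nitrogen in a ring, a large change of a 10-fold lower number from compound 1 to compound 2 (1.02 log units; beyond the scatter). The ethyl group is also lost in compound 3, but the group that replaces it differs, so this guide is indirect. A moderate step towards a lower number is therefore expected in this assay, smaller than the measured one. The expected change is a 3.4-fold lower number from compound 1 to compound 3 (0.53 log units; beyond the scatter). For compound 3 the estimated value is 11000 nM, with an expected range of 3000 nM to 35000 nM.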

Compound 3, half-maximal inhibitory concentration: 34000 nM
Estimate against measurement, compound 3: 3.1-fold (0.49 log units) below; measured number inside the range.
By their numbers in this assay, from the lowest: compound 2; then compounds 3 and 1 (each within the scatter of the next).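

In this assay the step from 4-ethylpiperazin-1-yl to morpholin-4-yl on the thiocarbonyl carbon gives a 1.1-fold lower number from compound 1 to compound 3 (0.04 log units; within the scatter), so these two rings cannot be told apart at this position. Losing the ethyl group is therefore not enough on its own to give a lower number; among the steps shown, only the one that brings in tert-butoxycarbonyl, a 10-fold lower number from compound 1 to compound 2 (1.02 log units; beyond the scatter), goes beyond the scatter. Nothing available explains why the morpholine and ethylpiperazine compounds read alike.

On these data alone, what remains open is whether the lower number of compound 2 needs the whole tert-butoxycarbonyl group or only a carbonyl on the ring nitrogen, which an acetyl group would test. A piperazine with a free amine, or a piperidine ring, would show how much that second ring nitrogen matters at this position.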